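Adding Chloro and the Cytotoxic Threshold in HEL Cells

The compounds below may be only part of what the source reports. "The series", "measured", "known", "first", "only" and "open" are said of these compounds alone.

Three compounds have been measured in a functional assay on HEL cells (Homo sapiens); a higher number here means that more compound is tolerated, a lower number that less compound is tolerated:

compound 1 `O=C1c2ccccc2N(Cc2ccccc2)S(=O)(=O)N1Cc1ccc(Cl)cc1`, giving 20000 nM
compound 2 `O=C1c2ccccc2N(Cc2ccccc2)S(=O)(=O)N1Cc1ccccc1`, giving > 50000 nM, which is a limit of the assay rather than a number
compound 3 `O=C1c2ccccc2N(Cc2ccccc2)S(=O)(=O)N1COCc1ccccc1`, giving 49000 nM

Compound 2 therefore stands only at a limit in this assay, as the limit of > 50000 nM in this assay, at which 1 of the 3 values shown sits, records, so its true position is not pinned down. Compound 4 `O=C1c2ccccc2N(Cc2cccc(Cl)c2)S(=O)(=O)N1Cc1ccccc1` differs from compound 2 by chloro in place of hydrogen on an aromatic carbon. The closest measured step is an at least 2.5-fold higher number from compound 1 to compound 2 (0.39 log units; beyond the scatter), where removing a chloro from the other benzyl group pushed the number upward to the limit; putting a chloro on a benzyl group is expected to work in the opposite direction here. The step of an at least 1.0-fold lower number from compound 2 to compound 3 (0.00 log units; that floor lies within the scatter) is within the scatter and gives no further guide. Compound 4 is therefore expected to show a lower number than compound 2, with the step estimated as an at least 1.6-fold lower number from compound 2 to compound 4 (0.22 log units; that floor lies within the scatter). For compound 4 the estimate in this assay is 30000 nM, ranging from 12000 nM to 60000 nM.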

Compound 4, minimum cytotoxic concentration: > 5000 nM
Compound 4: no number, only a limit; the forecaster's own chance of this, stated with the estimate: 35%; the middle value lies beyond the limit too.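

In this assay compound 4 gives > 5000 nM, which is a limit and not a number. Compound 2 gives > 50000 nM, also a limit. For the compounds shown here, no step can therefore be read between compound 2 and compound 4. From the compounds shown here alone, whether chloro in place of hydrogen here shifts the tolerated concentration at all stays open.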